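This account rests on a few compounds, and the source may have more. Where it says the series, first, only, none or still open, it means among the compounds named here.

In a functional assay on HCT-116 cells (Homo sapiens) for inhibition, read by MTT assay, with a stated time of 2 days, tested at 100 uM (a higher number here means more inhibition of growth at the concentration tested, a lower number less inhibition of growth), three compounds sharing one core have been measured. Compound 1 `CNC(=O)c1cc(Oc2ccc3nc(NC(=O)Nc4cc(C(F)(F)F)cc(C(F)(F)F)c4)sc3c2)ccn1` gives 98.4%. Compound 2 `CNC(=O)c1cc(Oc2ccc3nc(NC(=O)c4ccc(Cl)cc4Cl)sc3c2)ccn1` gives 64.4%. Compound 3 `CNC(=O)c1cc(Oc2ccc3nc(NC(=O)c4cc(Cl)cc(Cl)c4)sc3c2)ccn1` gives 15.8%. Going by the values given here, the one step between neighbours that differ in a single place is a number 48.6 percentage points lower from compound 2 to compound 3 (beyond the scatter), a large drop that lies beyond the scatter. Compound 3 therefore stands lowest of the three, with compound 2 the nearest above it and compound 1 furthest above it.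

Compound 4 `CNC(=O)c1cc(Oc2ccc3nc(NC(=O)Nc4ccc(Cl)cc4Cl)sc3c2)ccn1` has not yet been measured. It differs from compound 3 in one place: (2,4-dichlorophenyl)amino in place of 3,5-dichlorophenyl on a carbonyl carbon. This change undoes the chlorine arrangement that the step from compound 2 to compound 3 showed to be costly, and at the same time brings in an amino link of the kind that compound 1, the highest of the three, also carries. Among the compounds with values here, on the single step that bears on it, the swap back to 2,4-dichlorophenyl alone would be expected to recover a large part of the gap between compound 3 and compound 2.

Compound 4 is therefore expected to show a number 64.2 percentage points higher from compound 3 to compound 4 (beyond the scatter), a large rise in this assay. The estimate for compound 4 is 80%, with a range from 55% to 99%.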

Compound 4, percent growth inhibition at one concentration: 93.6%
The estimate for compound 4 lay 13.6 percentage points below the measured number; the measured number falls inside the stated range.
By their numbers in this assay, from the lowest: compound 3; then compound 2; then compounds 4 and 1 (each within the scatter of the next).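

In this assay, going by these compounds alone, the cleanest reading of this position comes from keeping the 2,4-dichlorophenyl group and adding only the amino link on the carbonyl carbon, which gives a number 29.2 percentage points higher from compound 2 to compound 4 (beyond the scatter), so the link itself goes with a gain that the earlier steps could not isolate. The full change gives a number 77.8 percentage points higher from compound 3 to compound 4 (beyond the scatter), a rise that combines the new link with the return to the 2,4-dichlorophenyl pattern, and so it shows that these two changes together turn the low end of this small set into a high number. Nothing available here explains why the amino link goes with higher growth inhibition.

As far as these compounds go, how (3,5-dichlorophenyl)amino would read at this place stays open, and without that partner the step from compound 3 to compound 4 cannot be divided between the chlorine pattern and the link. From the compounds shown here alone, it is also open whether the gain depends on an aromatic ring on the amino link, or would carry over to a cyclohexyl group or a short alkyl chain there.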